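Moving the hydroxymethyl group around the pyridine on the alkyne

A few compounds are considered here, and "the series" means these few. Any claim that something is new, unique, unknown or untested is made for them only; others in the source may bear on it.

Measured compounds:
compound 1 `Cc1ccc(-n2nccn2)c(C(=O)N2C[C@H](C#Cc3ccc(CO)nc3)CC[C@H]2C)c1`: 150 nM
compound 2 `Cc1ccc(-n2nccn2)c(C(=O)N2C[C@H](C#Cc3cnccc3O)CC[C@H]2C)c1`: 7.5 nM
compound 3 `Cc1ccc(-n2nccn2)c(C(=O)N2C[C@H](C#Cc3cccnc3O)CC[C@H]2C)c1`: 24 nM

All three share one core and differ only in the aromatic ring carried on the triple-bonded carbon. In an assay on cells for binding affinity to Orexin receptor type 2 (Homo sapiens), read by radioligand binding (on this read-out higher numbers stand for weaker inhibition and lower numbers for stronger inhibition), compound 1 gives the highest number of the three, so it is the weakest binder here. Replacing its ring by a hydroxypyridine lowered the number strongly: a 20-fold lower number from compound 1 to compound 2 (1.30 log units; beyond the scatter) and a 6.3-fold lower number from compound 1 to compound 3 (0.80 log units; beyond the scatter), and the two hydroxy positions themselves differ, a 3.2-fold higher number from compound 2 to compound 3 (0.51 log units; beyond the scatter). Compound 4 `Cc1ccc(-n2nccn2)c(C(=O)N2C[C@H](C#Cc3cc(CO)ccn3)CC[C@H]2C)c1` is not yet measured. It keeps the same atoms as compound 1 but joins them differently: 4-(hydroxymethyl)pyridin-2-yl in place of 6-(hydroxymethyl)pyridin-3-yl on a triple-bonded carbon. For the measured compounds named here, no measured step moves a hydroxymethyl group within the ring, so the steps above only show that this ring position is sensitive; they do not tell the direction. Compound 4 is therefore expected to stay near compound 1, with a broad range, estimated at 110 nM (range 30 nM to 400 nM), meaning an expected 1.4-fold lower number from compound 1 to compound 4 (0.13 log units; within the scatter).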

Compound 4, inhibition constant: 42 nM
Beside the measured number, compound 4's estimate is 2.6-fold (0.42 log units) above it; the range from low to high includes it.
By their numbers in this assay, from the lowest: compound 2; then compounds 3 and 4 (each within the scatter of the next); then compound 1.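

Keeping the hydroxymethyl group and only rearranging the same atoms is enough to lower the number in this assay (a 3.6-fold lower number from compound 1 to compound 4 (0.55 log units; beyond the scatter)), whereas every earlier step also exchanged hydroxymethyl for hydroxy, so the arrangement of the ring alone matters at this position. The new ring also reaches the range of one hydroxypyridine (a 1.8-fold higher number from compound 3 to compound 4 (0.24 log units; within the scatter)), though not that of the other, which keeps the lower number (a 5.6-fold higher number from compound 2 to compound 4 (0.75 log units; beyond the scatter)). Nothing available explains why the rearranged ring behaves this way.

The ring attachment and the hydroxymethyl position change together between 6-(hydroxymethyl)pyridin-3-yl and 4-(hydroxymethyl)pyridin-2-yl, so the contribution of each remains unresolved. Also open, going by these compounds, is how an aminomethyl group or a carboxylic acid in place of the hydroxymethyl group would read in this assay.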